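Swapping an Aryl Group on a Shared Quinone-Like Scaffold

The source may report more compounds than this note shows. Statements on the series, on what has been measured and on what is new or still open speak of the compounds shown alone.

Compound 1 `O=C1C(Nc2ccc(Br)cc2)=CC(=O)c2c1nc1n2[C@H]2OC[C@@H](O)[C@H]2OC1`: 5220 nM
Compound 2 `COc1ccccc1NC1=CC(=O)c2c(nc3n2[C@H]2OC[C@@H](O)[C@H]2OC3)C1=O`: 7460 nM
Compound 3 `COc1ccccc1NC1=CC(=O)c2nc3n(c2C1=O)[C@H]1OC[C@@H](O)[C@H]1OC3`: 2950 nM

In a functional assay on HeLa cells (Homo sapiens) for inhibition, read by sulforhodamine B assay (a higher number here means a weaker inhibitor, a lower number a stronger inhibitor), compound 1 gives 5220 nM, compound 2 gives 7460 nM and compound 3 gives 2950 nM. Compound 2 and compound 3 share the same atoms joined differently; the difference between the two cores is not broken down here. The change 4-bromophenyl in place of 2-methoxyphenyl on an amine nitrogen gave a 1.4-fold lower number from compound 2 to compound 1 (0.16 log units; within the scatter). Compound 4 `O=C1C=C(Nc2ccc(Br)cc2)C(=O)c2c1nc1n2[C@H]2OC[C@@H](O)[C@H]2OC1` is not yet measured; it differs from compound 3 by 4-bromophenyl in place of 2-methoxyphenyl on an amine nitrogen, the same change made on the core of compound 3. Because the earlier step was a 1.4-fold lower number from compound 2 to compound 1 (0.16 log units; within the scatter), the step for compound 4 is expected to be similar, a 1.4-fold lower number from compound 3 to compound 4 (0.15 log units; within the scatter). For compound 4 the estimated value in this assay is 2100 nM, expected between 1000 nM and 4500 nM.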

Compound 4, half-maximal inhibitory concentration: 3830 nM
Estimate against measurement, compound 4: 1.8-fold (0.26 log units) below; the range from low to high includes it.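

In this assay, putting 4-bromophenyl in place of 2-methoxyphenyl on the amine nitrogen gave a 1.3-fold higher number from compound 3 to compound 4 (0.11 log units; within the scatter), so the two compounds cannot be told apart here. Set beside the same swap on the other core, the two steps agree as closely as repeated measurements allow: the same change on two cores in this assay, a 1.4-fold lower number (0.16 log units; within the scatter) from compound 2 to compound 1 and a 1.3-fold higher number (0.11 log units; within the scatter) from compound 3 to compound 4, 1.9-fold (0.27 log units) apart, within the scatter of two such steps. This shows that on both cores the two aryl groups give results within the scatter, but it does not show that the same would hold on any further core or for a swap with a larger effect.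

On these data alone, it remains open what a different group on that nitrogen, such as a longer alkyl chain or a phenyl ring carrying a carboxylic acid, would do. Such a group might give a step that stands clear of the scatter, and only then could a real carry-over between cores be tested.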